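Carboxy in place of fluoro: expected solubility

The source may report more compounds than this note shows. Statements on the series, on what has been measured and on what is new or still open speak of the compounds shown alone.

Compound 1 `COc1ccc(Nc2cc3[nH]c(-c4cccc(C(F)(F)F)c4)nc3cn2)nc1` and compound 2 `Fc1ccc(Nc2cc3[nH]c(-c4cccc(C(F)(F)F)c4)nc3cn2)nc1` share one core. In a physicochemical assay for solubility, using the shake flask method, in phosphate buffer, measured as kinetic solubility, with a stated time of 20 h, at pH 6.5 (on this read-out lower numbers stand for lower solubility and higher numbers for higher solubility), compound 1 gives only a limit, < 5000 nM. Compound 2 likewise returns only a limit in this assay, < 5000 nM. The step that the two limits leave unreadable from compound 1 to compound 2 is thus not readable, as the limit of < 5000 nM in this assay, at which 2 of the 2 values shown sit, shows. Compound 3 `O=C(O)c1ccc(Nc2cc3[nH]c(-c4cccc(C(F)(F)F)c4)nc3cn2)nc1` differs from compound 2 by carboxy in place of fluoro on an aromatic carbon. Within the data shown here, no measured step gives a readable size for this change, so the expectation rests on the two limits alone. Compound 3 is expected to move past that limit, a step of an at least 4.0-fold higher number from compound 2 to compound 3 (0.60 log units; beyond the scatter). For compound 3 the estimate is 20000 nM, range 3000 nM to 150000 nM.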

Compound 3, solubility: 6000 nM
Estimate against measurement, compound 3: 3.3-fold (0.52 log units) above; the measured number falls inside the stated range.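

Compound 3, with 5-carboxypyridin-2-yl in place of 5-fluoropyridin-2-yl, is the only compound shown that gives a number rather than a limit in this assay. Carboxy in place of fluoro gives an at least 1.2-fold higher number from compound 2 to compound 3 (0.07 log units; that floor lies within the scatter), and carboxy in place of methoxy gives an at least 1.2-fold higher number from compound 1 to compound 3 (0.07 log units; that floor lies within the scatter). Both are floors only, and the true size of either step cannot be read: the limit of < 5000 nM in this assay, at which 2 of the 3 values shown sit.

Open, going by these compounds, is whether an amine or a primary amide on the same aromatic carbon also gives a number rather than a limit in this assay. On these data alone, a longer chain ending in a carboxylic acid at this place is equally open.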